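Furan-2-yl for pyridin-4-yl on the carbonyl carbon

The compounds below may be only part of what the source reports. "The series", "measured", "known", "first", "only" and "open" are said of these compounds alone.

Values in an ADME assay on cells (Hepatocyte, Homo sapiens) for metabolic stability (on this read-out higher numbers stand for a longer-lived compound and lower numbers for a shorter-lived compound), are as follows
- Compound 1 `O=C(NC1CCC(CN2CCN(c3cc(=O)c4cc(C(F)(F)F)cc([N+](=O)[O-])c4s3)CC2)CC1)c1ccccc1` gives > 1.55 h (a limit)
- Compound 2 `O=C(OC1CCC(CN2CCN(c3cc(=O)c4cc(C(F)(F)F)cc([N+](=O)[O-])c4s3)CC2)CC1)c1ccncc1` gives 0.075 h (a number)

Within the data shown here, compound 2 at 0.075 h holds the only actual number so far. The value of compound 1 is a limit. Compound 3 `O=C(OC1CCC(CN2CCN(c3cc(=O)c4cc(C(F)(F)F)cc([N+](=O)[O-])c4s3)CC2)CC1)c1ccco1` follows from compound 2 by furan-2-yl in place of pyridin-4-yl on a carbonyl carbon in a change that sets furan-2-yl in place of pyridin-4-yl on a carbonyl carbon. Among the measured compounds shown here, the one measured step of an at least 20-fold lower number from compound 1 to compound 2 (1.31 log units; beyond the scatter) was large, but it put ((pyridin-4-yl)carbonyl)oxy in place of benzamido on a saturated ring carbon. It leaves the group on the carbonyl carbon untested. No change beyond the scatter is therefore expected in this assay. The expectation stays close to compound 2 at 0.075 h as its anchor. The expected step of a 1.2-fold higher number from compound 2 to compound 3 (0.08 log units; within the scatter) lies within the scatter. Estimated for compound 3 is 0.09 h with 0.04 h to 0.25 h as the expected range.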

Compound 3, half-life: 0.075 h
Compound 3: middle estimate off by 1.2-fold (0.08 log units), on the high side; the measured number falls inside the stated range.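

In this assay, furan-2-yl in place of pyridin-4-yl on the carbonyl carbon gives no change at the digits printed from compound 2 to compound 3 (within the scatter), so the short half-life of compound 2 is not tied to pyridin-4-yl: the five-membered and six-membered aromatic rings read alike at this position. The drop from the benzamido compound now appears a second time, as an at least 20-fold lower number from compound 1 to compound 3 (1.31 log units; beyond the scatter), with ((furan-2-yl)carbonyl)oxy in place of benzamido on a saturated ring carbon. Compound 1 carries a limit, not a number: the limit of > 1.55 h in this assay, at which 1 of the 3 values shown sits.

Compounds 2 and 3 each differ from compound 1 in both the linking group and the ring, so the compounds shown do not separate these two parts; a furan-2-yl amide would do so. From the compounds shown here alone, it also remains open whether a non-aromatic group on the carbonyl carbon, such as cyclohexyl or a short alkyl chain, would read the same.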